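The source may report more compounds than this note shows. Statements on the series, on what has been measured and on what is new or still open speak of the compounds shown alone.

Working notes on the series in a functional assay on the whole organism (strain Wistar) for inhibition, with Rattus norvegicus as the target, read by paw edema, with stated times of 30 min and 3 h, at a dose of 200 mg/kg by the oral route; on this read-out lower numbers stand for less inhibition and higher numbers for more inhibition at the one dose given (going by the name of the read-out). Compound 1 `O=C(O)c1cc(-c2cc3c(n2-c2ccccc2)CCCC3)ccc1O` gives 25.8%. Within the data shown here, compound 2 `CCCCn1c(-c2ccc(O)c(C(=O)O)c2)cc2c1CCCC2` gives 41%, and the one measured step, a number 15.2 percentage points higher from compound 1 to compound 2 (beyond the scatter), is a modest gain. Compound 3 `COC(=O)c1cc(-c2cc3c(o2)CCCC3)ccc1O` gives 9.8%, the lowest of the three numbers, lying beyond the scatter below compound 1 and still further below compound 2.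

The next compound, compound 4 `O=C(O)c1cc(-c2cc3c(o2)CCCC3)ccc1O`, differs from compound 3 by hydrogen in place of methyl on an oxygen next to a carbonyl group. Among the measured compounds shown here, no measured step covers this change: the step from phenyl to butyl on an aromatic nitrogen concerns a different place and does not bear on it. What the values show is that both carboxy-bearing compounds, compound 1 at 25.8% and compound 2 at 41%, stand higher than the methoxycarbonyl-bearing compound 3 at 9.8%, though each also differs from it in its core. For compound 4 a rise is therefore expected, a number 12.2 percentage points higher from compound 3 to compound 4 (beyond the scatter), with an estimate of 22% and a range from 8% to 36%.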

Compound 4, a percentage reported as inhibition, in the whole organism at one dose (the size of the read-out at that dose, not a potency): 21.5%
Compound 4: the middle estimate sits 0.5 percentage points above what was measured, and the stated range covers the measured number.
By their numbers in this assay, from the lowest: compound 3; then compounds 4 and 1 (each within the scatter of the next); then compound 2.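

With this assay, the change from methyl to hydrogen on an oxygen next to a carbonyl group now has a direct reading on a single core: a number 11.7 percentage points higher from compound 3 to compound 4 (beyond the scatter), a modest gain. Unlike the earlier contrast between carboxy and methoxycarbonyl compounds, this pair differs in that one place alone, so the core plays no part in the step. No measurement on hand explains the gain.

The step rests on one pair, which leaves open whether the same change gives a step of like size on the cores of compound 1 and compound 2. Also open, from the compounds shown here alone, is where an ethyl group or a longer chain on that oxygen, or an amide in place of the carboxy group, would fall relative to compound 3 and compound 4.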